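Methoxy to methylsulfanyl: one swap on a chalcone-like compound

The source may hold more compounds than are shown below. What is called first, only, known or untested is meant among the compounds shown, and "the series" means these compounds.

Title correction: Methoxy to methylsulfanyl in a single swap

Compound 1 `COc1cc(O)c(C(=O)/C=C/c2ccc(F)cc2)c(OC)c1`: 12400 nM
Compound 2 `COc1cc(OC)c(C(=O)/C=C/c2ccccc2OC)c(OC)c1`: 4200 nM

Both compounds were tested in a functional assay on HCT-116 cells (Homo sapiens) for cytotoxicity, with a stated time of 48 h; a higher number here means a weaker inhibitor, a lower number a stronger inhibitor. Compound 2 has the lower of the two numbers, and its gap to compound 1 lies beyond the usual scatter of repeated measurements. Going by the values given here, with only two values, this says little about any trend, and the two compounds differ in more than one place.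

The next compound, compound 3 `COc1cc(OC)c(C(=O)/C=C/c2ccccc2SC)c(OC)c1`, keeps the shared core of compound 2 and changes a single group. Methylsulfanyl stands in place of methoxy on an aromatic carbon, ortho to a large group (methylsulfanyl in place of methoxy on an aromatic carbon). Among the compounds with values here, no measured pair shows this exchange, so there is no direct guide to its effect. The best reference is compound 2 at 4200 nM, and no change beyond the scatter is expected in this assay. The expected size of the move is a 1.1-fold lower number from compound 2 to compound 3 (0.02 log units; within the scatter). For compound 3 the estimated value is 4000 nM, with an expected range from 1400 nM to 12000 nM.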

Compound 3, half-maximal inhibitory concentration: 6800 nM
The estimate for compound 3 lay 1.7-fold (0.23 log units) below the measured number; low and high end bracket the measured number.
By their numbers in this assay, from the lowest: compounds 2, 3 and 1 (each within the scatter of the next, the first and the last beyond it).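

Placing methylsulfanyl instead of methoxy on this aromatic carbon, ortho to a large group, gives a 1.6-fold higher number from compound 2 to compound 3 (0.21 log units; within the scatter) in this assay. Compound 1 and compound 2 differ in more than one place, so they could not show what any single group contributes, whereas this pair isolates one exchange: 2-methoxyphenyl to 2-(methylsulfanyl)phenyl. At this position, swapping the oxygen of the methoxy group for the sulfur of methylsulfanyl produces no difference that can be told apart from the variation between repeated measurements, and no supporting measurement is available to explain this result.

This single pair cannot show whether the position accepts a wide range of groups or only close relatives of methoxy, and an amine, a carboxylic acid or a longer chain such as ethoxy on the same carbon would test that much more sharply. It also leaves open whether the same exchange would read the same way on a different aromatic carbon, or on a compound with other groups on the shared core.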